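The source may hold more compounds than are shown below. What is called first, only, known or untested is meant among the compounds shown, and "the series" means these compounds.

Measured so far:
compound 1 `COc1cc(/C=C2\CN(C)C/C(=C\c3cc(OC)c(OC)c(OC)c3)C2=O)cc(OC)c1OC` gives 1500 nM
compound 2 `COc1ccc(/C=C2\CN(C)C/C(=C\c3ccc(OC)c(OC)c3)C2=O)cc1OC` gives 9000 nM

Both numbers come from a functional assay on NCI-H1650 cells (Homo sapiens) for cytotoxicity, read by MTT assay, with a stated time of 72 h; a higher number here means a weaker inhibitor, a lower number a stronger inhibitor. Compound 1 stands at the lower of the two; the number for compound 2 is higher, and that gap lies beyond the usual scatter. Compound 3 `COc1cc(/C=C2\CN(C(=O)C(C)C)C/C(=C\c3cc(OC)c(OC)c(OC)c3)C2=O)cc(OC)c1OC` is not yet measured. It differs from compound 1 in one place: isopropylcarbonyl in place of methyl on an amine nitrogen in a ring. Among the compounds with values here, no measured pair in this set carries a comparable change, so the direction rests on judgment only. A moderate shift toward a higher number, beyond the scatter, is expected: a 2.3-fold higher number from compound 1 to compound 3 (0.37 log units; beyond the scatter). Compound 3 is estimated at 3500 nM, with a range of 900 nM to 14000 nM.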

Compound 3, half-maximal inhibitory concentration: 10800 nM
Compound 3: middle estimate off by 3.1-fold (0.49 log units), on the low side; measured number inside the range.
By their numbers in this assay, from the lowest: compound 1; then compounds 2 and 3 (each within the scatter of the next).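

In this assay, the amine nitrogen in the ring proves sensitive to substitution: isopropylcarbonyl in place of methyl gives a 7.2-fold higher number from compound 1 to compound 3 (0.86 log units; beyond the scatter) on the core of compound 1. Within the data shown here, this is the first single-place step, and it marks this change as unfavourable at this position, though it rests on one pair only. No measurement at hand accounts for the step.

Open, on these data alone, is whether acetyl, or a longer alkyl chain such as butyl, on this nitrogen would track with methyl or with isopropylcarbonyl. As far as these compounds go, whether the same step holds with the substitution pattern of compound 2 also remains open.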